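Nitro in place of isopropyl: an untested change

A few compounds are considered here, and "the series" means these few. Any claim that something is new, unique, unknown or untested is made for them only; others in the source may bear on it.

In a physicochemical assay for solubility, read by spectrophotometry, in phosphate buffer, with a stated time of 18 h, at pH 7.4 (a lower number here means a less soluble compound, a higher number a more soluble compound), compound 3 (`Cc1nn(-c2ccccc2)c2nc(-c3ccc(C(C)C)cc3)c(C#N)c(-c3ccccc3O)c12`) gives 9800 nM, within the scatter of compound 1 (`CCc1ccc(-c2nc3c(c(C)nn3-c3ccccc3)c(-c3ccccc3OC(F)(F)F)c2C#N)cc1`) at 9900 nM. Compound 2 (`C#Cc1ccccc1-c1c(C#N)c(-c2ccc(CC)cc2)nc2c1c(C)nn2-c1ccccc1`) stands apart at 46000 nM. Compound 4 (`Cc1nn(-c2ccccc2)c2nc(-c3ccc([N+](=O)[O-])cc3)c(C#N)c(-c3ccccc3O)c12`) carries nitro in place of isopropyl on an aromatic carbon, para to a large group: nitro in place of isopropyl on an aromatic carbon. Going by the values given here, the only measured step, a 4.6-fold higher number from compound 1 to compound 2 (0.67 log units; beyond the scatter), swaps ethynyl for trifluoromethoxy, so it involves neither group and offers only a rough sense of scale. Among the compounds with values here, no measured pair tests this change, so the expectation stays close to compound 3 at 9800 nM. The step expected, none beyond the scatter, is a 1.2-fold higher number from compound 3 to compound 4 (0.09 log units; within the scatter). Compound 4 is estimated at 12000 nM, with an expected range of 4000 nM to 35000 nM.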

Compound 4, solubility: 6000 nM
Estimate against measurement, compound 4: 2.0-fold (0.30 log units) above; measured number inside the range.
By their numbers in this assay, from the lowest: compounds 4, 3 and 1 (each within the scatter of the next); then compound 2.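

In this assay, going by these compounds alone, going from 4-isopropylphenyl to 4-nitrophenyl gives a 1.6-fold lower number from compound 3 to compound 4 (0.21 log units; within the scatter) and so stays within the scatter, the first measured step at this position. Across this pair, isopropyl and nitro, alike in heavy-atom count but differing in hydrogen-bond acceptors, cannot be told apart in this read-out. No measurement shown offers an explanation for this result.

Open, going by these compounds, is whether an amine or a carboxylic acid at this position would give a step beyond the scatter. Also open, on these data alone, is whether the same exchange reads alike with trifluoromethoxy or ethynyl on the neighbouring aryl group of the shared core.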